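Swapping the aminopyridine for a chloro-alkoxyaniline

This account rests on a few compounds, and the source may have more. Where it says the series, first, only, none or still open, it means among the compounds named here.

Compound 1 `COc1ncc(-c2ccc3ncnc(Nc4ccc(OCCCO)nc4)c3c2)cc1NS(=O)(=O)c1ccc(F)cc1F`: 3680 nM
Compound 2 `CCCCS(=O)(=O)Nc1cc(-c2ccc3ncnc(Nc4ccc(OCCO)nc4)c3c2)cnc1OC`: > 20000 nM

The two measured compounds share a core and are read in a functional assay on HCT-116 cells (Homo sapiens) for antiproliferative activity, read by sulforhodamine B assay, with a stated time of 72 h; on this read-out lower numbers stand for stronger inhibition and higher numbers for weaker inhibition. For the measured compounds named here, compound 1 gives 3680 nM, and this is the only number in hand. For compound 2 the assay reports only > 20000 nM, which is a limit of the assay and not a number (the limit of > 20000 nM in this assay, at which 1 of the 2 values shown sits). Going by the values given here, with that, compound 1 stands as the one compound with a measured value.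

Compound 3 `COc1ncc(-c2ccc3ncnc(Nc4ccc(OCCO)c(Cl)c4)c3c2)cc1NS(=O)(=O)c1ccc(F)cc1F` is not yet measured. It differs from compound 1 by 3-chloro-4-(2-hydroxyethoxy)phenyl in place of 6-(3-hydroxypropoxy)pyridin-3-yl on a nitrogen on an aromatic ring. Among the compounds with values here, no step between measured compounds that differ in one place is on hand, so the size of this change must be guessed from the structural change alone. He expects the step from compound 1 to compound 3 to be toward stronger inhibition, beyond the usual scatter, a 3.7-fold lower number from compound 1 to compound 3 (0.57 log units; beyond the scatter). He estimates that compound 3 will give 1000 nM in this assay, within a range from 300 nM to 4000 nM.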

Compound 3, half-maximal inhibitory concentration: 7320 nM
Compound 3: middle estimate off by 7.3-fold (0.86 log units), on the low side, outside the stated range (above it).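

In this assay, putting 3-chloro-4-(2-hydroxyethoxy)phenyl in place of 6-(3-hydroxypropoxy)pyridin-3-yl on the nitrogen gives a 2.0-fold higher number from compound 1 to compound 3 (0.30 log units; within the scatter). For the compounds shown here, this is the first readable step, and it shows that, on this pair alone, the position takes a chlorinated ring of carbon only with a shorter chain and no change that stands clear of repeated measurement. Nothing measured here bears on why the two groups read alike.

The compounds shown leave open how this step divides among its parts, as the ring, the chlorine and the chain all change in it at once, and a group such as 3-chloro-4-(3-hydroxypropoxy)phenyl would hold the chain fixed while the ring changes. Also open, from the compounds shown here alone, is whether a dimethylamino group in place of the hydroxy group on the chain, or a longer chain such as 4-hydroxybutoxy, would move the number beyond the usual scatter in this assay.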